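Amide replacements on the shared core: toward compound 4

The source may report more compounds than this note shows. Statements on the series, on what has been measured and on what is new or still open speak of the compounds shown alone.

Compound 1 `Cc1nc(C(=O)Nc2ccc(Cl)c(-c3nnc4c(Cl)cccn34)c2)cs1` gives > 100000 nM in a functional assay on MDA-MB-468 cells (Homo sapiens) for antiproliferative activity, read by MTT assay, with a stated time of 72 h; on this read-out higher numbers stand for weaker inhibition and lower numbers for stronger inhibition; that is a limit of the assay, not a number.
Compound 2 `O=C(Nc1ccc(Cl)c(-c2nnc3c(Cl)cccn23)c1)c1cccc(Cl)c1` gives 54800 nM in this assay.
Compound 3 `O=C(Nc1ccc(Cl)c(-c2nnc3c(Cl)cccn23)c1)c1ccccc1` gives > 100000 nM in this assay; that too is a limit, not a number.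

Compound 1 thus stands only at a limit, with no number of its own, and the limit of > 100000 nM in this assay, at which 2 of the 3 values shown sit, shows that the same holds for one further compound. Compound 4 `O=C(Nc1ccc(Cl)c(-c2nnc3c(Cl)cccn23)c1)c1ccccc1Cl` differs from compound 1 by 2-chlorophenyl in place of 2-methyl-1,3-thiazol-4-yl on a carbonyl carbon. Within the data shown here, two measured steps bear on this change. Moving to a chlorophenyl amide gave an at least 1.8-fold lower number from compound 1 to compound 2 (0.26 log units; that floor lies within the scatter), while moving to plain phenyl gave a step that the two limits leave unreadable from compound 1 to compound 3. Between the two phenyl amides, the chloro group is what separates them: an at least 1.8-fold higher number from compound 2 to compound 3 (0.26 log units; that floor lies within the scatter). Compound 4 carries its chlorine on a 2-chlorophenyl rather than the 3-chlorophenyl of compound 2, and whether that placement brings the same small gain cannot be read from these three compounds. With two of three values at the limit, only a weak effect is expected. In this assay compound 4 is estimated at 80000 nM, within 30000 nM to 200000 nM. The expected step is an at least 1.2-fold lower number from compound 1 to compound 4 (0.09 log units; that floor lies within the scatter), not beyond the scatter, and a further limit rather than a number is about as likely as not.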

Compound 4, half-maximal inhibitory concentration: > 100000 nM
Compound 4: only a limit was reported (the forecaster's own chance of this, stated with the estimate: 50%); at least 1.2-fold (0.09 log units) between middle value and limit.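

The change from 3-chlorophenyl to 2-chlorophenyl on the carbonyl carbon gives an at least 1.8-fold higher number from compound 2 to compound 4 (0.26 log units; that floor lies within the scatter). Among these compounds, a chlorine on the phenyl amide therefore does not in itself give a value under the limit, and compound 2 remains the only compound of the four with a number of its own, although the floor of this step stays within the scatter. The steps that link compound 4 to compound 1 and to compound 3 cannot be read, since both ends of each are limits, and the series now offers little room for comparison: the limit of > 100000 nM in this assay, at which 3 of the 4 values shown sit.

As far as these compounds go, it remains open whether any other group on the carbonyl carbon, such as a phenyl ring carrying a primary amine or a carboxylic acid, would give a value clearly separated from this limit in this assay. Also open, from the compounds shown here alone, is how much the chloro groups on the shared core contribute, as all four compounds carry them.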